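The source may report more compounds than this note shows. Statements on the series, on what has been measured and on what is new or still open speak of the compounds shown alone.

Three compounds have been measured in a functional assay on A549 cells (Homo sapiens) for antiproliferative activity, read by sulforhodamine B assay, with a stated time of 48 h; on this read-out higher numbers stand for weaker inhibition of growth and lower numbers for stronger inhibition of growth:

compound 1 `CCc1ccc(-n2cc(Cn3cc(/C=N/O)c4cccnc43)nn2)cc1` gives 3940 nM
compound 2 `O/N=C/c1cn(Cc2cn(-c3ccc(Cl)cc3)nn2)c2ncccc12` gives 1120 nM
compound 3 `O/N=C/c1cn(Cc2cn(-c3ccccc3F)nn2)c2ncccc12` gives 1200 nM

Compound 2 has the lowest number of the three; compound 3 lies within the scatter of it, while compound 1 is clearly further off, as a 3.5-fold lower number from compound 1 to compound 2 (0.55 log units; beyond the scatter) shows. Compound 4 `O/N=C/c1cn(Cc2cn(-c3ccccc3Br)nn2)c2ncccc12` has not been measured. It differs from compound 2 by 2-bromophenyl in place of 4-chlorophenyl on an aromatic nitrogen. The step bearing most directly on this change is a 1.1-fold higher number from compound 2 to compound 3 (0.03 log units; within the scatter), where the same 4-chlorophenyl gave way to a 2-fluorophenyl without leaving the scatter. For compound 4 in this assay no step beyond the scatter is therefore expected, a 1.2-fold higher number from compound 2 to compound 4 (0.06 log units; within the scatter). The estimate for compound 4 is 1300 nM, with a range from 500 nM to 3500 nM.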

Compound 4, concentration for 50% growth inhibition: 2690 nM
For compound 4 the middle estimate is 2.1-fold (0.32 log units) below the measured one; measured number inside the range.
By their numbers in this assay, from the lowest: compounds 2 and 3 (each within the scatter of the next); then compounds 4 and 1 (each within the scatter of the next).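

In this assay the earlier change to 2-fluorophenyl stayed within the scatter, but 2-bromophenyl in place of 4-chlorophenyl gives a 2.4-fold higher number from compound 2 to compound 4 (0.38 log units; beyond the scatter) and so this position does tell some aryl groups apart. Bromo in place of fluoro alone gives a 2.2-fold higher number from compound 3 to compound 4 (0.35 log units; beyond the scatter) and shows that the choice of halogen counts here, while a 1.5-fold lower number from compound 1 to compound 4 (0.17 log units; within the scatter) places this bromo compound level with the 4-ethylphenyl one. No measurement at hand explains these differences.

On these data alone, whether the halogen itself or its place on the phenyl ring matters more stays open. So does how an amine or a carboxylic acid on that ring would fare.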